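This account rests on a few compounds, and the source may have more. Where it says the series, first, only, none or still open, it means among the compounds named here.

Measured in a functional assay on MKN-45 cells (Homo sapiens) for cytotoxicity, read by MTT assay, with a stated time of 72 h; on this read-out lower numbers stand for stronger inhibition and higher numbers for weaker inhibition:
compound 1 `CN(C)CCn1cnnc1-c1cc(Oc2ccc(NC(=O)N/N=C/c3c(Cl)cccc3Cl)cc2F)ccn1` gives 160 nM
compound 2 `CN(C)CCn1cnnc1-c1cc(Oc2ccc(NC(=O)N/N=C/c3cccc(Cl)c3Cl)cc2F)ccn1` gives 51 nM
compound 3 `CN(C)CCn1cnnc1-c1cc(Oc2ccc(NC(=O)N/N=C/c3cccc(Br)c3)cc2F)ccn1` gives 450 nM

On these three numbers compound 3 stands highest. Its nearest neighbour is compound 1 a 2.8-fold higher number from compound 1 to compound 3 (0.45 log units; beyond the scatter), and its furthest is compound 2 an 8.8-fold higher number from compound 2 to compound 3 (0.95 log units; beyond the scatter); both steps lie beyond the scatter, so compound 3 is the weakest of the measured set in this assay. The remaining measured step, a 3.1-fold lower number from compound 1 to compound 2 (0.50 log units; beyond the scatter), also falls on the same aryl group.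

Compound 4 `CN(C)CCn1cnnc1-c1cc(Oc2ccc(NC(=O)N/N=C/c3ccc(O)cc3O)cc2F)ccn1` differs from compound 3 in one place: 2,4-dihydroxyphenyl in place of 3-bromophenyl on a carbon with a double bond to nitrogen. Among the compounds with values here, all three measured steps concern substitution of this same ring and are of modest size, which shows that this position moves the number, but none of them introduces hydroxy groups, so no direct precedent exists for the new ring. The direction of the step in this assay is therefore open; a modest shift, rather than a large one, is the expectation, and a number in the range already spanned by the set or somewhat beyond it.

Compound 4 is expected to give an estimated 600 nM, with a range from 120 nM to 3000 nM, corresponding to an expected step of a 1.3-fold higher number from compound 3 to compound 4 (0.12 log units; within the scatter).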

Compound 4, half-maximal inhibitory concentration: 2860 nM
The estimate for compound 4 lay 4.8-fold (0.68 log units) below the measured number, within the range that was stated.
By their numbers in this assay, from the lowest: compound 2; then compound 1; then compound 3; then compound 4.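

In this assay the aryl group on a carbon with a double bond to nitrogen can move the number further than the halogen-bearing rings suggested: there is a 6.4-fold higher number from compound 3 to compound 4 (0.80 log units; beyond the scatter), an 18-fold higher number from compound 1 to compound 4 (1.25 log units; beyond the scatter) and a 56-fold higher number from compound 2 to compound 4 (1.75 log units; beyond the scatter), which makes compound 4 the weakest of the four. The earlier steps compared only chlorine- or bromine-bearing rings, whereas 2,4-dihydroxyphenyl carries no halogen and has 2 hydrogen-bond donors and 2 hydrogen-bond acceptors against 0 of each for 3-bromophenyl, so this position is shown to be far less tolerant of this exchange than of the changes among the halogenated rings. No measurement at hand accounts for the rise in the number.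

Compound 4 removes the halogen and adds both hydroxy groups in one change, so the part played by each hydroxy group and by the loss of halogen stays unresolved. Also open, going by these compounds, is how this assay would read a ring bearing one hydroxy group, methoxy groups in place of the hydroxy groups, or an amine on the ring.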